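Methoxy for Carboxy on the Biphenyl Arm

The source may hold more compounds than are shown below. What is called first, only, known or untested is meant among the compounds shown, and "the series" means these compounds.

Compound 1 `Cc1ccccc1-n1nc(C)c2c1NC(=O)[C@H](C)S[C@@H]2c1ccc(-c2cccc(C(=O)O)c2)cc1` carries a carboxy group on its outer phenyl ring and is recorded in an assay on isolated protein for agonist activity at Bile acid receptor (Homo sapiens), read by AlphaScreen, with a stated time of 30 min (on this read-out higher numbers stand for an effect only at larger amounts of compound and lower numbers for an effect already at smaller amounts), as "not active" (no number reported), so no number marks where it stands. Compound 4 `COc1cccc(-c2ccc([C@H]3S[C@@H](C)C(=O)Nc4c3c(C)nn4-c3ccccc3C)cc2)c1` keeps the shared core and its 2-methylphenyl on the nitrogen but differs in one place: methoxy in place of carboxy on an aromatic carbon. Within the data shown here, none of the measured steps touches this position. Among the measured compounds shown here, the only step between measured compounds, a 3.1-fold higher number from compound 2 to compound 3 (0.49 log units; beyond the scatter), concerns the group on the aromatic nitrogen, and its two compounds carry a phenoxy group rather than a phenyl with a substituent; compound 2 `CCc1ccccc1-n1nc(C)c2c1NC(=O)[C@H](C)S[C@@H]2c1ccc(Oc2ccccc2)cc1` gives 1100 nM in this assay, and compound 3 `Cc1ccc(-n2nc(C)c3c2NC(=O)[C@H](C)S[C@@H]3c2ccc(Oc3ccccc3)cc2)cc1` gives 3400 nM. These two show that members of this series with a neutral group in place of the acid do register a number in this assay, while compound 1 with its carboxy does not. The step from compound 1 to compound 4 therefore cannot be sized from a measured comparison; the direction is expected to be toward a measurable effect. For compound 4 a half-maximal effective concentration of 2500 nM is estimated, within a range of 500 nM to 15000 nM.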

Compound 4, half-maximal effective concentration: 1800 nM
The estimate for compound 4 lay 1.4-fold (0.14 log units) above the measured number; measured number inside the range.
By their numbers in this assay, from the lowest: compounds 2, 4 and 3 (each within the scatter of the next, the first and the last beyond it).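

In this assay, among these compounds, compound 1 stands as "not active" (no number reported) and so no step to compound 4 can be read. No evidence at hand bears on this result. The compounds shown leave open what other groups in place of carboxy would give on this core.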